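This account rests on a few compounds, and the source may have more. Where it says the series, first, only, none or still open, it means among the compounds named here.

Two compounds of the series carry a number in an assay on isolated protein for inhibition of thyroid hormone receptor beta (Homo sapiens), read by fluorescence, with a stated time of 30 min (a higher number here means a weaker inhibitor, a lower number a stronger inhibitor), so far. Compound 1 `CCCN(CC1CCOC1)C(=O)c1cc(Cl)c2oc(NCc3cccc(Cl)c3)nc2c1` gives 71 nM. Compound 2 `COc1cc(C(=O)N2CCCC2)cc2nc(NCc3cccc(Cl)c3)oc12` gives 180 nM; on these two numbers compound 2 stands highest, and its distance from compound 1 lies beyond the scatter of repeated measurement. Compound 3 `COc1cc(C(=O)N2CC[C@@H](O)C(C)(C)C2)cc2nc(NCc3cccc(Cl)c3)oc12` has not yet been measured. It differs from compound 2 in one place: 4-hydroxy-3,3-dimethylpiperidin-1-yl in place of pyrrolidin-1-yl on a carbonyl carbon. For the measured compounds named here, no pair of measured compounds shows this same change, so its effect in this assay cannot be read from the numbers in hand. The expected step from compound 2 to compound 3 is therefore small, a 1.1-fold higher number from compound 2 to compound 3 (0.05 log units; within the scatter), with no direction that should stand out beyond the scatter. For compound 3 the estimate in this assay is 200 nM, with a range from 60 nM to 700 nM.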

Compound 3, half-maximal inhibitory concentration: 35 nM
Compound 3: the middle estimate sits 5.7-fold (0.76 log units) above what was measured; measured number below the stated range.
By their numbers in this assay, from the lowest: compound 3; then compound 1; then compound 2.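

For the compounds shown here, on a carbonyl carbon whose other neighbour is an aromatic carbon, the group carried matters in this assay: 4-hydroxy-3,3-dimethylpiperidin-1-yl in place of pyrrolidin-1-yl gives a 5.1-fold lower number from compound 2 to compound 3 (0.71 log units; beyond the scatter), the first one-place step. The position therefore accepts the six-membered ring with its hydroxyl and two methyls without loss, and the step goes towards a stronger inhibitor. Nothing at hand explains why this change lowers the number.

The step changes ring size, hydroxyl and methyls at once, so the share of each stays unread; 4-hydroxypiperidin-1-yl, 3,3-dimethylpiperidin-1-yl and plain piperidin-1-yl would separate them. The role of the defined stereocentre also stays open, since the opposite configuration of the hydroxyl-bearing carbon is not among the compounds shown.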